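The source may hold more compounds than are shown below. What is called first, only, known or untested is meant among the compounds shown, and "the series" means these compounds.

Working notes on the series. Three compounds sharing one core have been run in a functional assay on the whole organism (strain Swiss) with Mus musculus as the target, with a stated time of 2 h, at a dose of 100 mg/kg; on this read-out lower numbers stand for a weaker effect and higher numbers for a stronger effect at the one dose given. Compound 3 `CC(C(=O)N1CCN(c2cccc(C(F)(F)F)c2)CC1)N1C(=O)CCC1=O` gives 75% and stands highest of the three measured numbers. Compound 1 `COCC(C(=O)N1CCN(c2cccc(C(F)(F)F)c2)CC1)N1C(=O)CCC1=O` gives 50%, and compound 2 `CCC(C(=O)N1CCN(c2cccc(C(F)(F)F)c2)CC1)N1C(=O)CCC1=O` gives 25%. The measured steps all concern the group on the saturated chain carbon: a number 25 percentage points lower from compound 1 to compound 2 (beyond the scatter), a number 25 percentage points higher from compound 1 to compound 3 (beyond the scatter) and a number 50 percentage points higher from compound 2 to compound 3 (beyond the scatter).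

Compound 4 `CC(C(=O)N1CCN(c2cccc(Cl)c2)CC1)N1C(=O)CCC1=O` has not yet been measured. It differs from compound 3 at the aromatic ring: chloro in place of trifluoromethyl on an aromatic carbon. Going by the values given here, no measured step touches the aromatic ring, so none of the three steps bears directly on this change. The working expectation is therefore that the step of a number 10 percentage points lower from compound 3 to compound 4 (within the scatter) from compound 3 to compound 4 is expected to stay within the scatter. The range around that expectation is kept wide, the aromatic substituent having not been varied among the measured compounds. For compound 4 the estimated value in this assay is 65%, with a range from 35% to 90%.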

Compound 4, a percentage reported as activity, at one dose (the size of the read-out at that dose, not a potency): 25%
For compound 4 the middle estimate is 40 percentage points above the measured one, outside the stated range (below it).
By their numbers in this assay, from the lowest: compounds 2 and 4 (each within the scatter of the next); then compound 1; then compound 3.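

In this assay, the aromatic carbon proves to be a position that matters: chloro in place of trifluoromethyl gives a number 50 percentage points lower from compound 3 to compound 4 (beyond the scatter). The earlier compounds shown here varied only the group on the saturated chain carbon, and this step is as large as the widest step seen there, a number 50 percentage points higher from compound 2 to compound 3 (beyond the scatter), so the read-out answers to the aromatic substituent as well as to the chain group. No available measurement gives a reason for this step.

The compounds shown leave open how a bromo, a nitrile or a methoxy on the same aromatic carbon would read. They also leave open whether the change from trifluoromethyl to chloro gives a step of similar size with methyl or methoxy, rather than hydrogen, on the saturated chain carbon.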